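Swapping an Amino Group for a Methoxy on a Furan Nucleoside

This account rests on a few compounds, and the source may have more. Where it says the series, first, only, none or still open, it means among the compounds named here.

Compound 3 `Nc1nc(N)c2c(-c3ccco3)cn([C@@H]3O[C@H](CO)[C@@H](O)[C@H]3O)c2n1` carries two amino groups on its shared core together with a furan-2-yl group. In a functional assay on HeLa S3 cells (Homo sapiens) for antiproliferative activity, read by XTT assay, with a stated time of 72 h (on this read-out higher numbers stand for weaker inhibition and lower numbers for stronger inhibition), compound 3 gives > 20000 nM, which is a limit of the assay rather than a number. Its thiophen-3-yl partner, compound 1 `Nc1nc(N)c2c(-c3ccsc3)cn([C@@H]3O[C@H](CO)[C@@H](O)[C@H]3O)c2n1`, gives > 20000 nM in this assay, again a limit. The step that the two limits leave unreadable from compound 1 to compound 3 therefore cannot be read, because of the limit of > 20000 nM in this assay, at which 2 of the 3 values shown sit. Compound 2 `COc1ncnc2c1c(-c1ccco1)cn2[C@@H]1O[C@H](CO)[C@@H](O)[C@H]1O`, which carries a single methoxy group and no amino group, gives 1020 nM in this assay, a number rather than a limit.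

The next step goes from compound 3 to compound 4 `COc1nc(N)nc2c1c(-c1ccco1)cn2[C@@H]1O[C@H](CO)[C@@H](O)[C@H]1O`, with methoxy in place of amino on an aromatic carbon. For the measured compounds named here, no measured step bears directly on this change. Going by the values given here, the only guidance comes from compound 2, which with a methoxy group gives 1020 nM in this assay. Compound 3, by contrast, stands at its limit. The expected step is an at least 6.6-fold lower number from compound 3 to compound 4 (0.82 log units; beyond the scatter), toward stronger inhibition. Compound 4 is estimated to give about 3000 nM in this assay, within a range from 700 nM to 15000 nM.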

Compound 4, half-maximal inhibitory concentration: > 20000 nM
Compound 4 ended at the assay's limit (the forecaster's own chance of this, stated with the estimate: 20%); at least 6.6-fold (0.82 log units) between middle value and limit.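

Compound 4 pairs the methoxy group of compound 2 with the amino group that compound 2 lacks, and in this assay compound 4 gives > 20000 nM, which is a limit of the assay and not a number. The steps from one limit to another cannot be read, so nothing can be said about the size of the change from amino to methoxy, because neither end gives a number: the limit of > 20000 nM in this assay, at which 3 of the 4 values shown sit. The readable comparison is amino in place of hydrogen on an aromatic carbon, which gives an at least 19-fold higher number from compound 2 to compound 4 (1.29 log units; beyond the scatter), toward weaker inhibition, so with that amino group present a methoxy group does not bring a readable value.

Going by these compounds, whether an ethoxy or a methylamino group in the same place would give a number remains open. So does the effect of a methyl group in place of the remaining amino group.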